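The source may report more compounds than this note shows. Statements on the series, on what has been measured and on what is new or still open speak of the compounds shown alone.

In an ADME assay on microsomes from liver (Homo sapiens) for metabolic stability, using NADPH, with a stated time of 10 min (on this read-out higher numbers stand for a more stable compound and lower numbers for a less stable compound), compound 1 `NCCCCN(C[C@H]1Cc2cccnc2CN1)[C@H]1CCCc2cccnc21` gives 96%. Compound 2 `NC(=O)NCCCCN(C[C@H]1Cc2ncccc2CN1)[C@H]1CCCc2cccnc21` gives 91% in this assay; the two numbers lie within the scatter of each other, so compound 2 cannot be told apart from compound 1 on this read-out, and both sit near the top of the scale. Compound 3 `c1cnc2c(c1)CN[C@@H](CN(CCCCNC1CCOCC1)[C@H]1CCCc3cccnc31)C2` has not yet been measured in this assay. It differs from compound 2 in one place: oxan-4-yl in place of carbamoyl on an amine nitrogen. For the measured compounds named here, with no pair of measured compounds sharing this change, the data give no direct guide to its size, and the two measured numbers alone point only to a high level. The step from compound 2 to compound 3 is expected to be a number 6 percentage points lower from compound 2 to compound 3 (within the scatter), at most a modest loss, likely not far beyond the scatter. Compound 3 is therefore expected to give 85% in this assay, with a plausible range from 65% to 97%.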

Compound 3, percent of the compound remaining: 97%
The estimate for compound 3 lay 12 percentage points below the measured number; the range from low to high includes it.
By their numbers in this assay, from the lowest: compounds 2, 1 and 3 (each within the scatter of the next).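

Replacing carbamoyl with oxan-4-yl on an amine nitrogen gives, in this assay, a number 6 percentage points higher from compound 2 to compound 3 (within the scatter). For the compounds shown here, this is the first direct comparison at this position, and it shows that a non-aromatic six-membered ring of 6 heavy atoms can take the place of a ring-free group of 3 heavy atoms with no measurable difference on this read-out. The hydrogen-bond donor and the double bond counted in carbamoyl are absent from oxan-4-yl, yet compound 2 and compound 3 still cannot be told apart here. Nothing shown explains this result.

As far as these compounds go, it remains open whether a different group on this nitrogen, such as a carboxylic acid, a piperidine ring or a longer chain, would also leave the read-out unchanged. A single pair also cannot show whether this swap would behave the same way on a different core.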